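The source may report more compounds than this note shows. Statements on the series, on what has been measured and on what is new or still open speak of the compounds shown alone.

Compound 1 `CCN(c1ccc(C#N)c(Cl)c1)c1cc(-c2cccs2)ccc1C` is one of two compounds in this set with a number in a functional assay on CWR22R cells (Homo sapiens) for antiproliferative activity, read by CCK-8 assay, with a stated time of 6 days; on this read-out higher numbers stand for weaker inhibition and lower numbers for stronger inhibition. In this assay compound 1 gives 22000 nM. For the measured compounds named here, of those two numbers, the one for compound 1 is the larger, but the nearest entry, compound 2 `N#Cc1ccc(N2CCCc3c(-c4ccncc4)cccc32)cc1C(F)(F)F` with 15000 nM in this assay, lies within the usual scatter of it, so the two cannot be told apart. Compound 3 `N#Cc1ccc(N2CCc3cc(-c4cncnc4)ccc3C2)cc1C(F)(F)F` has no reported result in this assay, where its entry reads "not determined" (no result reported).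

Compound 4 `CCN(c1ccc(C#N)c(Cl)c1)c1cc(-n2cccn2)ccc1C` differs from compound 1 in a single place: 1H-pyrazol-1-yl in place of thiophen-2-yl on an aromatic carbon. Going by the values given here, no pair of measured compounds here shares this change, so nothing in the data shows how swapping 1H-pyrazol-1-yl for thiophen-2-yl on that aromatic carbon affects this assay. With weak inhibition already seen for compound 1 at 22000 nM, the expectation is a small step in either direction, most likely not beyond the scatter. For compound 4 the estimated value in this assay is 25000 nM, with a range from 8000 nM to 80000 nM. That estimate corresponds to an expected step of a 1.1-fold higher number from compound 1 to compound 4 (0.06 log units; within the scatter).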

Compound 4, half-maximal inhibitory concentration: > 30000 nM
Compound 4 ended at the assay's limit; the forecaster's own chance of this, stated with the estimate: 25%; middle value at least 1.2-fold (0.07 log units) from the limit.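

In this assay compound 4 gives > 30000 nM, which is a limit of the assay and not a number. Putting 1H-pyrazol-1-yl in place of thiophen-2-yl on this aromatic carbon, para to a methyl group, gives an at least 1.3-fold higher number from compound 1 to compound 4 (0.13 log units; that floor lies within the scatter), so this change brings no sign of stronger inhibition, though its true size stays hidden. With two five-membered aromatic rings now tried at this position, neither gives strong inhibition, and only a floor can be read for the step: the limit of > 30000 nM in this assay, at which 1 of the 4 values shown sits.

As far as these compounds go, it remains open whether a different kind of group on this carbon, such as an amine, a carboxylic acid or a plain phenyl ring, would bring the number down. A single swap also cannot show whether the same change would act alike on another core.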